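Trading an aryl for a methyl on the ring nitrogen

This account rests on a few compounds, and the source may have more. Where it says the series, first, only, none or still open, it means among the compounds named here.

Three compounds share one core and were tested in a functional assay on HeLa cells (Homo sapiens) for antiproliferative activity, read by CCK-8 assay, with a stated time of 72 h, tested at 2 uM; on this read-out higher numbers stand for a stronger effect at the one concentration tested and lower numbers for a weaker effect. Compound 1 `Nc1ccccc1NC(=O)c1ccc(CSC(=S)N2CCN(c3ccccc3)CC2)cc1` gives 62.2%, compound 2 `Nc1ccccc1NC(=O)c1ccc(CSC(=S)N2CCc3ccccc32)cc1` gives 38%, and compound 3 `Nc1ccccc1NC(=O)c1ccc(CSC(=S)N2CCN(c3cccnc3)CC2)cc1` gives 66.2%. Compound 3 and compound 1 lie within the scatter of each other, while compound 2 sits beyond the scatter below both. Compound 4 `CN1CCN(C(=S)SCc2ccc(C(=O)Nc3ccccc3N)cc2)CC1` differs from compound 3 by methyl in place of pyridin-3-yl on an amine nitrogen in a ring. For the measured compounds named here, the only step at this position, a number 4 percentage points higher from compound 1 to compound 3 (within the scatter), swaps one aromatic ring for another, so it says little about exchanging an aromatic ring for a methyl. Going by the values given here, with no direct precedent, the direction in this assay is uncertain, and a drop is a fair guess. Compound 4 is therefore estimated at 45%, ranging from 25% to 65%, a step of a number 21.2 percentage points lower from compound 3 to compound 4 (beyond the scatter).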

Compound 4, a percentage reported as inhibition, at one concentration (the size of the read-out at that concentration, not a potency): 52.6%
Beside the measured number, compound 4's estimate is 7.6 percentage points below it, within the range that was stated.
By their numbers in this assay, from the lowest: compound 2; then compounds 4, 1 and 3 (each within the scatter of the next, the first and the last beyond it).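

In this assay, methyl in place of pyridin-3-yl gives a number 13.6 percentage points lower from compound 3 to compound 4 (beyond the scatter) while methyl in place of phenyl gives a number 9.6 percentage points lower from compound 1 to compound 4 (within the scatter) so an aromatic ring on this nitrogen is not needed to keep much of the effect. The 4-methylpiperazin-1-yl group in place of 2,3-dihydro-1H-indol-1-yl gives a number 14.6 percentage points higher from compound 2 to compound 4 (beyond the scatter) and so even this small substituent reads well above compound 2. No measurement here explains these shifts. Still open, from the compounds shown here alone, is how a butyl chain, a cyclohexyl ring or a benzyl group on this nitrogen would read out.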